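Cytotoxicity notes on a nucleoside series: compound 3 to compound 4

This account rests on a few compounds, and the source may have more. Where it says the series, first, only, none or still open, it means among the compounds named here.

Measured compounds:
compound 1 `CN(Cc1ccccc1)Cc1ncnc2c1ncn2[C@@H]1O[C@H](CO)[C@@H](O)[C@H]1O` in a functional assay on Huh-7 cells (Homo sapiens) for cytotoxicity, read by MTT assay, with a stated time of 3 days (a higher number here means that more compound is tolerated, a lower number that less compound is tolerated), gives 9000 nM.
compound 2 `O=C(O)CNCc1ncnc2c1ncn2[C@@H]1O[C@H](CO)[C@@H](O)[C@H]1O` in this assay gives > 100000 nM, a limit of the assay.
compound 3 `OCCSCc1ncnc2c1ncn2[C@@H]1O[C@H](CO)[C@@H](O)[C@H]1O` in this assay gives > 100000 nM, a limit of the assay.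

Compound 3 stands at the limit shown for two of the three values (the limit of > 100000 nM in this assay, at which 2 of the 3 values shown sit); its number is not read, only that it lies beyond the range measured. Compound 4 `OC[C@H]1O[C@@H](n2cnc3c(CN4CCCCC4)ncnc32)[C@H](O)[C@@H]1O` is not yet measured. The change is piperidin-1-yl in place of (2-hydroxyethyl)sulfanyl on a saturated chain carbon bound to an aromatic carbon, on a saturated chain carbon bound to an aromatic carbon.

Within the data shown here, the steps that bear on it run the other way: an at least 11-fold higher number from compound 1 to compound 3 (1.04 log units; beyond the scatter) and an at least 11-fold higher number from compound 1 to compound 2 (1.04 log units; beyond the scatter), both beyond the scatter, while a step that the two limits leave unreadable from compound 2 to compound 3 cannot be read. Among the measured compounds shown here, compound 1 carries a benzyl(methyl)amino group, a tertiary amine, and is the one compound with a number; compound 4 brings in piperidin-1-yl, also a tertiary amine. The step from compound 3 to compound 4 is therefore expected to be a lower number, an at least 3.3-fold lower number from compound 3 to compound 4 (0.52 log units; beyond the scatter), moving back toward where compound 1 sits rather than all the way. Compound 4 is estimated at 30000 nM, within 8000 nM to 100000 nM.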

Compound 4, half-maximal cytotoxic concentration: 87000 nM
The estimate for compound 4 lay 2.9-fold (0.46 log units) below the measured number; the range from low to high includes it.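

In this assay the change to piperidin-1-yl on a saturated chain carbon bound to an aromatic carbon gives a 9.7-fold higher number from compound 1 to compound 4 (0.99 log units; beyond the scatter) and shows that a tertiary amine at this place does not, by itself, bring the number down to that of compound 1. The steps from the two limit compounds are floors only, with an at least 1.1-fold lower number from compound 3 to compound 4 (0.06 log units; that floor lies within the scatter) and an at least 1.1-fold lower number from compound 2 to compound 4 (0.06 log units; that floor lies within the scatter) leaving compound 4 unordered against either. Compound 2 and compound 3 each stand at a limit of the assay, so the step between them cannot be read: the limit of > 100000 nM in this assay, at which 2 of the 4 values shown sit.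

As far as these compounds go, whether the lower number of compound 1 follows its benzyl group remains open. A benzylamino group without the methyl, or a morpholin-4-yl or dimethylamino group at the same place, would show how far this holds.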